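The compounds below may be only part of what the source reports. "The series", "measured", "known", "first", "only" and "open" are said of these compounds alone.

Working notes on the series built on the core of compound 1 `CC(C)n1nc(-c2cc(-c3ccccc3)on2)c2c(N)ncnc21`, all read in an assay on BaF3 cells for inhibition of proto-oncogene tyrosine-protein kinase receptor Ret (Homo sapiens), read by MTT assay, with a stated time of 48 h; on this read-out lower numbers stand for stronger inhibition of growth and higher numbers for weaker inhibition of growth. Compound 1 gives 3460 nM. Compound 2 `CC(C)n1nc(/C=N/O)c2c(N)ncnc21` reports only the limit of the assay, > 10000 nM. Compound 3 `CC(C)n1nc(-c2cc(-c3ccc(F)cc3)on2)c2c(N)ncnc21` likewise reports only the assay limit, > 10000 nM. Among the measured compounds shown here, the single measured step, fluoro in place of hydrogen on an aromatic carbon, runs an at least 2.8-fold higher number from compound 1 to compound 3 (0.46 log units; beyond the scatter) and ends at the limit of > 10000 nM in this assay, at which 2 of the 3 values shown sit, so its full size stays unknown. Compound 4 `CC(C)n1nc(-c2ccon2)c2c(N)ncnc21` differs from compound 3 by hydrogen in place of 4-fluorophenyl on an aromatic carbon. For the measured compounds named here, no measured step matches this change; compound 2, carrying its own small group, also sits at the limit. Compound 4 is therefore expected to stay weak, with a step that the limit leaves unreadable from compound 3 to compound 4 giving an estimated 15000 nM (range 4000 nM to 60000 nM).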

Compound 4, concentration for 50% growth inhibition: 3210 nM
Beside the measured number, compound 4's estimate is 4.7-fold (0.67 log units) above it, and the stated range ends above it.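

In this assay, hydrogen in place of phenyl on the aromatic carbon next to the ring oxygen gives a 1.1-fold lower number from compound 1 to compound 4 (0.03 log units; within the scatter), so phenyl on this carbon adds nothing readable to the number. Hydrogen in place of 4-fluorophenyl gives an at least 3.1-fold lower number from compound 3 to compound 4 (0.49 log units; beyond the scatter), which places the weak reading of compound 3 with that group, not with the shared core. The isoxazole-free group of compound 2 gives way to the bare five-membered ring in an at least 3.1-fold lower number from compound 2 to compound 4 (0.49 log units; beyond the scatter). On these data alone, the full size of these last two steps stays open: the limit of > 10000 nM in this assay, at which 2 of the 4 values shown sit. Whether an amine or a carboxylic acid on this carbon would move the number also remains open.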